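The compounds below may be only part of what the source reports. "The series", "measured", "known", "first", "only" and "open" are said of these compounds alone.

- Compound 1 `C=CS(=O)(=O)N1CCN(c2ncnc3sc(-c4ccc(C(F)(F)F)cc4)cc23)CC1`: 7080 nM
- Compound 2 `C=CS(=O)(=O)N1CCN(c2ncnc3sc(-c4ccc(N5CCN(C)CC5)cc4)cc23)CC1`: 8760 nM

In a functional assay on MDA-MB-436 cells (Homo sapiens) for antiproliferative activity, read by MTT assay, with a stated time of 48 h (a higher number here means a weaker inhibitor, a lower number a stronger inhibitor), compound 1 gives 7080 nM and compound 2 gives 8760 nM. Among the compounds with values here, these two values lie within the scatter of each other, so compound 1 has no clear rank against its only neighbour.

Compound 3 `C=CS(=O)(=O)N1CCN(c2ncnc3sc(-c4cccc5ncccc45)cc23)CC1` keeps the core of compound 1 and changes the group on the aromatic carbon next to the ring sulfur: quinolin-5-yl in place of 4-(trifluoromethyl)phenyl on an aromatic carbon.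

Within the data shown here, one measured step bears on this only indirectly: a 1.2-fold higher number from compound 1 to compound 2 (0.09 log units; within the scatter). Among the measured compounds shown here, that step swapped a group on the aromatic ring, whereas compound 3 replaces the whole 4-(trifluoromethyl)phenyl, a change no measured pair has tested. In this assay, no shift beyond the scatter is therefore expected, in either direction.

The expected change is a 1.0-fold lower number from compound 1 to compound 3 (0.00 log units; within the scatter). For compound 3 the estimated value is 7000 nM, with an expected range from 3000 nM to 16000 nM.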

Compound 3, half-maximal inhibitory concentration: 25900 nM
Estimate against measurement, compound 3: 3.7-fold (0.57 log units) below; measured number above the stated range.
By their numbers in this assay, from the lowest: compounds 1 and 2 (each within the scatter of the next); then compound 3.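

Swapping the whole 4-(trifluoromethyl)phenyl for quinolin-5-yl on the aromatic carbon next to the ring sulfur gives a 3.7-fold higher number from compound 1 to compound 3 (0.56 log units; beyond the scatter) in this assay, so the group at this position can shift the number, which the earlier change on the aromatic ring did not show. The two groups have the same count of heavy atoms, yet quinolin-5-yl carries a second six-membered aromatic ring, with one nitrogen and one hydrogen-bond acceptor, and no fluorine. Nothing available explains the rise in the number.

The swap changes several features at once, so the compounds shown cannot separate the contribution of the nitrogen from that of the second ring. A naphthalene ring, which has the two fused rings without the nitrogen, or a pyridine ring, which has the nitrogen without the second ring, at this carbon would address that open question.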